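The compounds below may be only part of what the source reports. "The series", "measured", "known", "first", "only" and "open" are said of these compounds alone.

Measured so far:
- compound 1, `O[C@H](COc1ccc(C(F)(F)F)cc1)CN1CCN(c2ccc(F)cc2)CC1`: 59.2%
- compound 2, `O[C@@H](COc1ccc(F)cc1)CN1CCN(c2ccc(F)cc2)CC1`: 47.5%
- compound 3, `O[C@H](COc1ccc(Cl)cc1)CN1CCN(c2ccc(F)cc2)CC1`: 28.3%

In an assay on HEK293 cells for inhibition of Voltage-dependent T-type calcium channel subunit alpha-1G (Homo sapiens), read by patch clamp, tested at 10 uM (on this read-out lower numbers stand for less inhibition and higher numbers for more inhibition at the one concentration tested (going by the name of the read-out)), compound 3 stands lowest of the three numbers; compound 2 is nearest, and compound 1 furthest, both beyond the scatter. Among the compounds with values here, the only one-place step measured, a number 30.9 percentage points lower from compound 1 to compound 3 (beyond the scatter), is large and comes from chloro in place of trifluoromethyl. Compound 4, `O[C@H](COc1ccc(F)cc1)CN1CCN(c2ccc(F)cc2)CC1`, is not yet measured. The change from compound 3 to compound 4 is fluoro in place of chloro on an aromatic carbon. Within the data shown here, no measured step covers this exact exchange; compound 2 also carries fluoro on the phenoxy ring and gives 47.5%, but no one-place step links compound 2 to compound 4, so its value is only a rough pointer. Among the measured compounds shown here, the one bearing step shows that a change at this position can move the read-out substantially, so a step in this assay of moderate size upward is expected, a number 11.7 percentage points higher from compound 3 to compound 4 (beyond the scatter). Compound 4 is estimated at 40%, within 22% to 58%.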

Compound 4, a percentage reported as inhibition, at one concentration (the size of the read-out at that concentration, not a potency): 50%
Compound 4: middle estimate off by 10 percentage points, on the low side; low and high end bracket the measured number.
By their numbers in this assay, from the lowest: compound 3; then compounds 2, 4 and 1 (each within the scatter of the next, the first and the last beyond it).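

In this assay, the change from 4-chlorophenoxy to 4-fluorophenoxy gives a clear step (a number 21.7 percentage points higher from compound 3 to compound 4 (beyond the scatter)), so the low number of compound 3 goes with chloro at this place and does not follow from every replacement of trifluoromethyl. Fluoro and trifluoromethyl are not separated on this ring (a number 9.2 percentage points lower from compound 1 to compound 4 (within the scatter)), which leaves chloro as the one substituent of the three that stands apart in this small set. At the saturated chain carbon, no difference between the two drawn configurations can be read (a number 2.5 percentage points higher from compound 2 to compound 4 (within the scatter)), and this comparison speaks to configuration alone because of one fact: the fact that compounds 2 and 4 differ only in the configuration as drawn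

As far as these compounds go, it remains open how an amine, a carboxylic acid or a methoxy group would read at this place, and whether the number of compound 3 would hold in the other configuration. From the compounds shown here alone, all numbers come from a single concentration, so potency remains unknown.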